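From isopropyl to cyclopentyl on the sulfonyl sulfur

The source may hold more compounds than are shown below. What is called first, only, known or untested is meant among the compounds shown, and "the series" means these compounds.

Measured so far in a functional assay on OVCAR-3 cells (Homo sapiens) for activation, with a stated time of 24 h; on this read-out higher numbers stand for an effect only at larger amounts of compound and lower numbers for an effect already at smaller amounts (lower numbers mean an effect at smaller amounts):
- compound 1 `CC(C)S(=O)(=O)c1cccc(NC(=O)c2cccnc2N2CCC3(CC2)CC3)c1` gives 4290 nM (higher of the two)
- compound 2 `CC(C)(C)NS(=O)(=O)c1cccc(NC(=O)c2ccc(NS(C)(=O)=O)cc2N2CCC3(CC2)CC3)c1` gives 16 nM (lower of the two)

Compound 1 stands at the top of these two numbers, and compound 2 lies far below it, well beyond the usual scatter. The two differ in more than one place, however, so their gap says nothing direct about any single change.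

The next compound, compound 3 `O=C(Nc1cccc(S(=O)(=O)C2CCCC2)c1)c1cccnc1N1CCC2(CC1)CC2`, has not yet been measured. It keeps the core of compound 1 and carries cyclopentyl in place of isopropyl on a sulfonyl sulfur. For the measured compounds named here, no measured pair isolates this change. In this assay the expectation is therefore a small step at most, probably within the scatter, with a slight lean towards lower numbers. The estimated move, a 1.2-fold lower number from compound 1 to compound 3 (0.09 log units; within the scatter), is correspondingly modest. For compound 3 the estimate is 3500 nM, with an expected range of 1200 nM to 10000 nM around it.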

Compound 3, half-maximal effective concentration: 1870 nM
Beside the measured number, compound 3's estimate is 1.9-fold (0.27 log units) above it, and the stated range covers the measured number.
By their numbers in this assay, from the lowest: compound 2; then compound 3; then compound 1.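

In this assay, for the compounds shown here, the exchange of isopropyl for cyclopentyl on the sulfonyl sulfur gives a 2.3-fold lower number from compound 1 to compound 3 (0.36 log units; beyond the scatter) and offers the first comparison here that isolates a single change. The step is modest but lies beyond the usual scatter, so the read-out responds to the group at this place, and the larger group, with its five-membered non-aromatic ring of carbon only, goes with an effect at smaller amounts, even though neither group carries hydrogen-bond donors or acceptors. Nothing measured here accounts for this step.

This single pair cannot separate the added carbon count from the ring itself, so an open chain such as n-pentyl, or a smaller ring such as cyclopropyl, would be needed to tell the two apart. As far as these compounds go, whether the trend continues to a larger ring such as cyclohexyl, or holds with an amine on the sulfonyl sulfur, also remains open.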